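The compounds below may be only part of what the source reports. "The series", "measured", "known", "first", "only" and "open" are said of these compounds alone.

Measured in a functional assay on microsomes for inhibition, with a stated time of 1 h; on this read-out higher numbers stand for weaker inhibition and lower numbers for stronger inhibition:
- compound 1 `CCOC(=O)c1cnn(-c2nc(-c3cccc(OC)c3OC)c(C#N)c(=O)n2C)c1N`: 57 ug/mL
- compound 2 `CCOC(=O)c1cnn(-c2nc(-c3ccccc3O)c(C#N)c(=O)n2C)c1N`: 57 ug/mL

Compound 2, at 57 ug/mL, stands level with compound 1 at the digits shown. The next change leads to compound 3 `CCOC(=O)c1cnn(-c2nc(-c3ccco3)c(C#N)c(=O)n2C)c1N`: furan-2-yl in place of 2-hydroxyphenyl on an aromatic carbon, ortho to a cyano group (furan-2-yl in place of 2-hydroxyphenyl on an aromatic carbon). Going by the values given here, one measured step bears on this carbon: no change at the digits printed from compound 1 to compound 2 (within the scatter). That step exchanged one substituted phenyl group for another, and no five-membered aromatic ring has been measured in the series, so the evidence for this change is thin. No step beyond the scatter is therefore expected in this assay, and no direction is favoured. The expected step is a 1.1-fold higher number from compound 2 to compound 3 (0.02 log units; within the scatter). For compound 3 the estimate is 60 ug/mL, with an expected range from 25 ug/mL to 130 ug/mL.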

Compound 3, half-maximal inhibitory concentration: 116 ug/mL
For compound 3 the middle estimate is 1.9-fold (0.29 log units) below the measured one; measured number inside the range.
By their numbers in this assay, from the lowest: compounds 1 and 2 (each within the scatter of the next); then compound 3.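

In this assay, the aromatic carbon ortho to a cyano group proves responsive to the group it carries: furan-2-yl gives a 2.0-fold higher number from compound 2 to compound 3 (0.31 log units; beyond the scatter), and the comparison with 2,3-dimethoxyphenyl gives a 2.0-fold higher number from compound 1 to compound 3 (0.31 log units; beyond the scatter). The two substituted phenyl groups stand level, so the shift towards weaker inhibition appears only when the six-membered aromatic ring of carbon only gives way to a five-membered aromatic ring with 1 hetero atom. No supporting measurement is available to account for this shift.

The compounds shown do not separate the effect of ring size from that of the ring's hetero atom, a question on which unsubstituted phenyl and thiophen-2-yl at this carbon would bear. Also open, from the compounds shown here alone, is how an amine or a carboxylic acid on the aromatic ring at this position would read out.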